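Changing the Acyl Group on a Shared Core

The source may report more compounds than this note shows. Statements on the series, on what has been measured and on what is new or still open speak of the compounds shown alone.

Going by the values given here, in a functional assay on KYSE-450 cells (Homo sapiens) for inhibition, read by MTT assay, with a stated time of 48 h (a higher number here means a weaker inhibitor, a lower number a stronger inhibitor), compound 2 `C/C=C/C(=O)N(Cc1ccc(OC)c(O)c1)c1cc(OC)c(OC)c(OC)c1` gives 67 nM, the lowest of the two numbers so far, while compound 1 `C#CC(=O)N(Cc1ccc(OC)c(O)c1)c1cc(OC)c(OC)c(OC)c1` gives 570 nM. Compound 3 `COc1ccc(CN(C(=O)CBr)c2cc(OC)c(OC)c(OC)c2)cc1O` keeps the shared core and has bromomethyl in place of prop-1-en-1-yl on a carbonyl carbon.

Among the compounds with values here, only one measured step bears on this place: an 8.5-fold lower number from compound 1 to compound 2 (0.93 log units; beyond the scatter), from prop-1-en-1-yl in place of ethynyl on a carbonyl carbon. That step shows that a change here can move the number beyond the scatter. Within the data shown here, no compound with bromomethyl has been measured, so the direction remains uncertain. A step of similar or smaller size is expected in this assay, leaning towards a higher number, as compound 2 already stands lowest at 67 nM. The expected change is a 1.6-fold higher number from compound 2 to compound 3 (0.22 log units; within the scatter). For compound 3 the estimate is 110 nM, within an expected range of 25 nM to 500 nM.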

Compound 3, half-maximal inhibitory concentration: 120 nM
The estimate for compound 3 lay 1.1-fold (0.04 log units) below the measured number, within the range that was stated.
By their numbers in this assay, from the lowest: compounds 2 and 3 (each within the scatter of the next); then compound 1.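

In this assay the swap of prop-1-en-1-yl for bromomethyl on the carbonyl carbon gives a 1.8-fold higher number from compound 2 to compound 3 (0.25 log units; within the scatter) and so leaves the two groups indistinguishable at this position. The swap of ethynyl for bromomethyl gives a 4.8-fold lower number from compound 1 to compound 3 (0.68 log units; beyond the scatter) and matches the earlier step in direction, so compound 1, with ethynyl, is now the weakest of the three, set apart from both of the others by more than the scatter. Nothing here gives a measured reason why these groups rank as they do.

What the compounds leave open is whether the bromine itself matters, since a plain methyl or a chloromethyl group on the same carbonyl carbon would be needed to test that. On these data alone, it is also open how far this position tolerates larger changes, such as an amine or a longer chain.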